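The compounds below may be only part of what the source reports. "The series", "measured", "known", "first", "only" and "open" are said of these compounds alone.

Among the measured compounds shown here, in a functional assay on CNE-2 cells (Homo sapiens) for antiproliferative activity, read by sulforhodamine B assay, with a stated time of 48 h (a lower number here means a stronger inhibitor, a higher number a weaker inhibitor), compound 1 `COc1ccc(C=C(C(=O)/C=C/c2cccc(OC)c2OC)C(=O)/C=C/c2cccc(OC)c2OC)cc1OC` gives 280 nM and compound 2 `COc1cc(OC)c(C=C(C(=O)/C=C/c2cccc(OC)c2OC)C(=O)/C=C/c2cccc(OC)c2OC)c(OC)c1` gives 630 nM as the higher of only two numbers, which makes compound 2 the weaker inhibitor so far. Compound 3 `COc1cc(C=C(C(=O)/C=C/c2cccc(OC)c2OC)C(=O)/C=C/c2cccc(OC)c2OC)cc(OC)c1O` keeps the shared core but changes the same site: 4-hydroxy-3,5-dimethoxyphenyl in place of 2,4,6-trimethoxyphenyl on a double-bonded chain carbon bound to a double-bonded chain carbon on a double-bonded chain carbon bound to a double-bonded chain carbon. For the measured compounds named here, the one measured step at this site, a 2.3-fold higher number from compound 1 to compound 2 (0.35 log units; beyond the scatter), was modest and brought in 2,4,6-trimethoxyphenyl along with the higher number. Going by the values given here, removing that group is therefore expected to lower the number modestly in this assay, although no measured compound carries 4-hydroxy-3,5-dimethoxyphenyl. The expected change is a 2.1-fold lower number from compound 2 to compound 3 (0.32 log units; beyond the scatter) here. Compound 3 is estimated at 300 nM, within a range of 100 nM to 800 nM as expected.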

Compound 3, half-maximal inhibitory concentration: 300 nM
Compound 3: the middle estimate sits on the measured number at the digits printed, and the stated range covers the measured number.
By their numbers in this assay, from the lowest: compounds 1 and 3 (each within the scatter of the next); then compound 2.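

In this assay the change to 4-hydroxy-3,5-dimethoxyphenyl gives a 2.1-fold lower number from compound 2 to compound 3 (0.32 log units; beyond the scatter) and, against 3,4-dimethoxyphenyl, a 1.1-fold higher number from compound 1 to compound 3 (0.03 log units; within the scatter). This position therefore takes a ring with a hydrogen-bond donor without a shift beyond the scatter, and of the three groups only 2,4,6-trimethoxyphenyl stands apart. Nothing available explains these differences.

As far as these compounds go, whether the hydroxyl or the methoxy groups of compound 3 set its number stays open. So does the outcome for a ring carrying an amine or a carboxylic acid at this position.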